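The source may hold more compounds than are shown below. What is called first, only, known or untested is meant among the compounds shown, and "the series" means these compounds.

Of the compounds shown here, three built on one shared core have been tested in a functional assay on K562 cells (Homo sapiens) for inhibition, read by MTT assay, with a stated time of 72 h; on this read-out higher numbers stand for weaker inhibition and lower numbers for stronger inhibition. Compound 1 `CCOC(=O)C1=C(Nc2ccccc2)S/C(=C\c2cc(OC)c(O)c(OC)c2)C1=O` gives 31700 nM. Compound 2 `CCOC(=O)C1=C(Nc2ccccc2)S/C(=C\c2ccc[nH]2)C1=O` gives 71000 nM, which is the higher of the two numbers in this assay; compound 1 lies below it by a gap that is beyond the usual scatter. Compound 3 `CCOC(=O)C1=C(Nc2ccc([N+](=O)[O-])cc2)S/C(=C\c2ccc[nH]2)C1=O` is reported only as a limit of this assay, > 100000 nM, and not as a number. That reading is described by the limit of > 100000 nM in this assay, at which 1 of the 3 values shown sits. The step of an at least 1.4-fold higher number from compound 2 to compound 3 (0.14 log units; that floor lies within the scatter) puts a nitro in place of hydrogen on an aromatic carbon of the aniline ring, and its floor lies within the scatter, so no firm direction can be read from it.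

Compound 4 `CCOC(=O)C1=C(Nc2cccc([N+](=O)[O-])c2)S/C(=C\c2ccc[nH]2)C1=O` has not yet been measured in this assay. It differs from compound 2 by nitro in place of hydrogen on an aromatic carbon. Among the compounds with values here, only the step from compound 2 to compound 3 bears on this change, since it brings the same nitro group onto the same ring at another carbon; that step was at least a small rise and may have been much larger. Compound 4 is therefore expected to show a number the same as or higher than compound 2, with a real chance that this assay reports only a limit. The estimate for compound 4 is 100000 nM, within a range of 40000 nM to 250000 nM, which is expected to mean a 1.4-fold higher number from compound 2 to compound 4 (0.15 log units; within the scatter).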

Compound 4, half-maximal inhibitory concentration: 7200 nM
Estimate against measurement, compound 4: 14-fold (1.14 log units) above, outside the stated range (below it).
By their numbers in this assay, from the lowest: compound 4; then compound 1; then compound 2. At a limit, above all of these: compound 3.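

In this assay, nitro in place of hydrogen, meta to a large group, gives a 9.9-fold lower number from compound 2 to compound 4 (0.99 log units; beyond the scatter), so this change can lower the number, which the earlier nitro step could not show. Exchanging the two nitro-bearing groups, 3-nitrophenyl in place of 4-nitrophenyl on the amine nitrogen, gives an at least 13-fold lower number from compound 3 to compound 4 (1.14 log units; beyond the scatter), so among these compounds the outcome of adding nitro depends on which ring carbon carries it. Compound 3 is held only as a limit, so that step gives a floor and not a full size: the limit of > 100000 nM in this assay, at which 1 of the 4 values shown sits.

The compounds shown leave open whether a different group at the same ring carbon, such as an amine, a nitrile or a carboxylic acid, would also lower the number, or whether this is particular to nitro. They also leave open whether 3-nitrophenyl in place of phenyl would have the same outcome in compound 1, which carries a different group at its other end, and whether a second nitro on the same ring would add to the step.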